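Swapping an Amine Linker for an Ether in a Cytotoxicity Series

The compounds below may be only part of what the source reports. "The series", "measured", "known", "first", "only" and "open" are said of these compounds alone.

Three measured compounds share one core and differ only in the ring attached through a saturated chain carbon to a ring nitrogen. In a functional assay on TK-10 cells (Homo sapiens) for inhibition, read by sulforhodamine B assay, with a stated time of 48 h (on this read-out higher numbers stand for lower toxicity in this test and lower numbers for higher toxicity in this test), compound 1 `Nc1cc(N)c2nc(-c3ccccc3)c(NCc3ccc(Cl)c(Cl)c3)nc2c1` gives 72400 nM. Compound 2 `Nc1cc(N)c2nc(-c3ccccc3)c(NCc3ccc(F)cc3)nc2c1` gives 53700 nM in this assay, a step of a 1.3-fold lower number from compound 1 to compound 2 (0.13 log units; within the scatter), so the two compounds sit within each other's scatter and neither can be called the more toxic. For compound 3 `COc1ccc(CNc2nc3cc(N)cc(N)c3nc2-c2ccccc2)cc1` this assay reports only a limit, < 100000 nM. The steps a step that the limit leaves unreadable from compound 1 to compound 3 and a step that the limit leaves unreadable from compound 2 to compound 3 therefore cannot be sized (the limit of < 100000 nM in this assay, at which 1 of the 3 values shown sits). Compound 4 `Nc1cc(N)c2nc(-c3ccccc3)c(Oc3ccc(F)cc3)nc2c1` carries 4-fluorophenoxy in place of (4-fluorobenzyl)amino on an aromatic carbon. Among the compounds with values here, no measured step touches the linker itself, so no sized step bears on this change. Compound 4 is expected to give about 60000 nM, estimated to range from 25000 nM to 140000 nM, an expected step of a 1.1-fold higher number from compound 2 to compound 4 (0.05 log units; within the scatter).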

Compound 4, concentration lethal to 50% of the cells: 64600 nM
Compound 4: the middle estimate sits 1.1-fold (0.03 log units) below what was measured, within the range that was stated.
By their numbers in this assay, from the lowest: compounds 2, 4 and 1 (each within the scatter of the next).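

Up to now, only the outer ring had varied while the amine link to the core stayed fixed, so compound 4 is the first to test the link itself. Exchanging (4-fluorobenzyl)amino for 4-fluorophenoxy on this aromatic carbon, which takes away the hydrogen-bond donor, gives a 1.2-fold higher number from compound 2 to compound 4 (0.08 log units; within the scatter) in this assay, so this test does not separate the two links. Nothing measured here bears on why this is so.

Open, from the compounds shown here alone, is whether a sulfur link, an amide or a longer chain at this carbon would read the same. Also open, going by these compounds, is whether the ether link would give a similar reading with 3,4-dichlorophenyl as the outer ring.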